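The source may hold more compounds than are shown below. What is called first, only, known or untested is meant among the compounds shown, and "the series" means these compounds.

In a functional assay on DU-145 cells (Homo sapiens) for antiproliferative activity, read by MTT assay, with a stated time of 24 h (on this read-out lower numbers stand for stronger inhibition and higher numbers for weaker inhibition), the three measured compounds stand as follows:

Compound 1, `COc1ccc(-c2cc(/C=C/C(=O)c3cc(OC)c(OC)c(OC)c3)nc3cc(-c4ccccc4)nn23)cc1OC`, gives 8300 nM.
Compound 2, `COc1cc(/C=C/C(=O)c2cc(-c3cc(OC)c(OC)c(OC)c3)n3nc(-c4ccccc4)cc3n2)cc(OC)c1OC`, gives 17900 nM.
Compound 3, `COc1ccc(C(=O)/C=C/c2cc(-c3cc(OC)c(OC)c(OC)c3)n3nc(-c4ccccc4)cc3n2)cc1OC`, gives 29900 nM.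

Among these three numbers compound 3 has the highest. Its nearest neighbour is compound 2, whose number is lower by an amount within the usual scatter, so these two cannot be told apart on this read-out. Compound 1 lies furthest away, with a lower number beyond the scatter, so compound 1 inhibits more strongly than compound 3.

Compound 4, `COc1ccc(-c2cc(/C=C/C(=O)c3ccc(OC)c(OC)c3)nc3cc(-c4ccccc4)nn23)cc1`, has not yet been measured. It differs from compound 3 in one place: 4-methoxyphenyl in place of 3,4,5-trimethoxyphenyl on an aromatic carbon. Within the data shown here, no measured pair shows what this change alone does, so there is no direct guide from the data. The expected step from compound 3 to compound 4 in this assay is about a 1.2-fold higher number from compound 3 to compound 4 (0.07 log units; within the scatter), that is, nothing beyond the scatter, if anything a slight weakening. Compound 4 is therefore estimated to give 35000 nM in this assay, with a likely range from 12000 nM to 100000 nM.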

Compound 4, half-maximal inhibitory concentration: 16400 nM
The estimate for compound 4 lay 2.1-fold (0.33 log units) above the measured number; measured number inside the range.
By their numbers in this assay, from the lowest: compounds 1, 4, 2 and 3 (each within the scatter of the next, the first and the last beyond it).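

Among these compounds, this is the first single-place step at this position: in this assay, 4-methoxyphenyl in place of 3,4,5-trimethoxyphenyl, on the aromatic carbon next to the ring nitrogen, gives a 1.8-fold lower number from compound 3 to compound 4 (0.26 log units; within the scatter). So the smaller group, with fewer oxygen atoms, can stand at this position without a difference that this read-out can resolve, and the full 3,4,5-trimethoxyphenyl pattern is not shown to be needed here for this pair. Nothing available explains this outcome.

Going by these compounds, it remains open whether an unsubstituted phenyl, or a quite different group such as an amine or a carboxylic acid, would also be accepted at this position. On these data alone, it is equally open whether the same swap would give a similar step on the core of compound 1.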